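From phenyl to 4-bromophenyl on the shared core

The compounds below may be only part of what the source reports. "The series", "measured", "known", "first", "only" and "open" are said of these compounds alone.

Compound 1 `Cc1ccc(NCc2cn(-c3ccccc3)nc2-c2ccc(Cl)cc2)cc1` gives > 100000 nM as a limit
Compound 2 `FC(F)(F)c1ccc(NCc2cn(-c3ccccc3)nc2-c2ccc(Br)cc2)cc1` gives 20000 nM as a number
Compound 3 `Cc1ccc(NCc2cn(-c3ccccc3)nc2-c2ccccc2)cc1` gives > 100000 nM as a limit

In an ADME assay on BHK-21 cells (Mesocricetus auratus) for cytotoxicity, read by MTT assay, with a stated time of 72 h (on this read-out lower numbers stand for higher toxicity in this test and higher numbers for lower toxicity in this test), compound 3 gives > 100000 nM as a limit and not as a number. Compound 1 gives > 100000 nM in this assay and that too is a limit. The set thus shows the limit of > 100000 nM in this assay, at which 2 of the 3 values shown sit, and offers no number for compound 3.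

Compound 4 `Cc1ccc(NCc2cn(-c3ccccc3)nc2-c2ccc(Br)cc2)cc1` follows from compound 3 by one change, bromo in place of hydrogen on an aromatic carbon and so phenyl turns into 4-bromophenyl. Among the measured compounds shown here, the one measured step involving a halogen in this way is a step that the two limits leave unreadable from compound 1 to compound 3 and it gives no size to carry over. For the measured compounds named here, compound 2 also carries 4-bromophenyl and gives 20000 nM as the only number in the set, so a modest move toward lower numbers is the most that can be expected. The expected change is an at least 1.2-fold lower number from compound 3 to compound 4 (0.09 log units; that floor lies within the scatter) and it remains uncertain. For compound 4 the estimated value is 80000 nM with an expected range from 30000 nM to 100000 nM and a report at the limit would be no surprise.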

Compound 4, half-maximal cytotoxic concentration: > 100000 nM
Compound 4 ended at the assay's limit (the forecaster's own chance of this, stated with the estimate: 55%); at least 1.2-fold (0.09 log units) between middle value and limit.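

With 4-bromophenyl held in place, methyl in place of trifluoromethyl on an aromatic carbon gives an at least 5.0-fold higher number from compound 2 to compound 4 (0.69 log units; beyond the scatter) in this assay. Bromo at this position therefore does not by itself bring a measurable number, since compound 4 gives > 100000 nM, which is a limit, and the only compound with a number is compound 2, the only one carrying trifluoromethyl. The steps from compound 3 and from compound 1 to compound 4 cannot be read, and the set now shows: the limit of > 100000 nM in this assay, at which 3 of the 4 values shown sit.

The compounds shown leave open how far compounds 1, 3 and 4 differ beyond that limit, and whether trifluoromethyl would give a number without bromo. They also leave open what an amine or a carboxylic acid in place of the methyl would do in this assay.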